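Halogen swap on the phenoxy ring in an antiproliferative series

The compounds below may be only part of what the source reports. "The series", "measured", "known", "first", "only" and "open" are said of these compounds alone.

compound 1 `Cc1nn(C)c(Oc2ccc(I)cc2)c1/C=N\CCCCCOc1cc2oc(=O)cc(C)c2cc1Cl` — > 25000 nM
compound 2 `Cc1nn(C)c(Oc2cccc(F)c2)c1/C=N\CCCCCCOc1cc2oc(=O)cc(C)c2cc1Cl` — > 25000 nM

Both measured compounds were tested in a functional assay on U-87MG ATCC cells for antiproliferative activity against U-87 MG (Homo sapiens), read by MTT assay, with a stated time of 72 h; on this read-out lower numbers stand for stronger inhibition and higher numbers for weaker inhibition. For compound 1 the result is a limit of the assay, > 25000 nM, not a number. For compound 2 the result is likewise a limit, > 25000 nM. Compound 2 thus stands at the edge of what the assay reports, and the same holds for compound 1, as the limit of > 25000 nM in this assay, at which 2 of the 2 values shown sit, records. For the measured compounds named here, no step between measured compounds can be computed: compound 1 and compound 2 differ in more than one place, and both sit at the limit, so what they show is only that neither reaches measurable inhibition.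

Compound 3 `Cc1nn(C)c(Oc2cccc(Br)c2)c1/C=N\CCCCCCOc1cc2oc(=O)cc(C)c2cc1Cl` follows from compound 2 by bromo in place of fluoro on an aromatic carbon. With both measured compounds at the limit, no direction for this change can be read from the values, and the expected step from compound 2 to compound 3 is a step that the limit leaves unreadable from compound 2 to compound 3, none beyond the scatter, with a high chance that only a limit is reported again. Compound 3 is therefore estimated at 30000 nM, between 8000 nM and 120000 nM.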

Compound 3, half-maximal inhibitory concentration: 3610 nM
For compound 3 the middle estimate is 8.3-fold (0.92 log units) above the measured one; the measured number lies below the stated range.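

In this assay, the change from 3-fluorophenoxy to 3-bromophenoxy yields the only measured number among the compounds shown, a change of an at least 6.9-fold lower number from compound 2 to compound 3 (0.84 log units; beyond the scatter). The earlier compounds shown here, both at the limit, gave no sign that any substituent could bring a value into the readable range; this pair shows that the halogen on the aromatic carbon meta to a large group can do so, with the rest of the structure unchanged. The size of the step is only a bound, because the value of compound 2 is a limit and not a number: the limit of > 25000 nM in this assay, at which 2 of the 3 values shown sit.

Still open, on these data alone, is whether the trend depends on halogen identity at this place or extends to other groups, such as trifluoromethyl or methoxy, and whether bromo at this place would give a similar result with a shorter or longer chain. Compound 1 differs from compound 3 in more than one place, so it cannot settle either question.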